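Replacing Ethyl with Furanoyl on the Shared Core

The source may hold more compounds than are shown below. What is called first, only, known or untested is meant among the compounds shown, and "the series" means these compounds.

Compound 1 `CCOC(=O)c1cnc(CC)nc1NN1C(=O)C=C(C)C1=O` is the reference point of this small series. In a functional assay on Jurkat cells for inhibition of nuclear factor NF-kappa-B complex (Homo sapiens) (a lower number here means a stronger inhibitor, a higher number a weaker inhibitor), compound 1 gives 10000 nM, the highest number among the three measured compounds. Compound 2 `CCOC(=O)c1cnc(-c2cccc(OC)c2)nc1NN1C(=O)C=C(C)C1=O` gives 5000 nM in this assay, and compound 3 `CCOC(=O)c1cnc(-c2ccc(Cl)cc2)nc1NN1C(=O)C=C(C)C1=O` gives 300 nM. Both measured steps away from compound 1 replace the same ethyl group: a 2.0-fold lower number from compound 1 to compound 2 (0.30 log units; within the scatter), whereas a 33-fold lower number from compound 1 to compound 3 (1.52 log units; beyond the scatter). Between the two aryl analogues, a 17-fold lower number from compound 2 to compound 3 (1.22 log units; beyond the scatter).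

Compound 4 `CCOC(=O)c1cnc(C(=O)c2ccco2)nc1NN1C(=O)C=C(C)C1=O` is not yet measured. It differs from compound 1 as follows: (furan-2-yl)carbonyl in place of ethyl on an aromatic carbon. Both measured steps from compound 1 bear on it, since each swaps the ethyl for a group that contains an aromatic ring; one stayed within the scatter and the other was large. A (furan-2-yl)carbonyl group is a different change from either, so a moderate drop in number is expected, with wide uncertainty: a 3.3-fold lower number from compound 1 to compound 4 (0.52 log units; beyond the scatter). Compound 4 is expected to give 3000 nM in this assay, within a range from 700 nM to 12000 nM.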

Compound 4, half-maximal inhibitory concentration: 700 nM
Beside the measured number, compound 4's estimate is 4.3-fold (0.63 log units) above it; the range from low to high includes it.
By their numbers in this assay, from the lowest: compound 3; then compound 4; then compounds 2 and 1 (each within the scatter of the next).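

At this aromatic carbon between two ring nitrogen atoms, a large gain in this assay is no longer confined to the 4-chlorophenyl group, as the (furan-2-yl)carbonyl group also gives one, with a 14-fold lower number from compound 1 to compound 4 (1.15 log units; beyond the scatter). Among the three larger groups the outcome still depends on which group enters: there is a 7.1-fold lower number from compound 2 to compound 4 (0.85 log units; beyond the scatter), so the new group clearly outperforms 3-methoxyphenyl, the one replacement that stayed within the scatter of ethyl, while a 2.3-fold higher number from compound 3 to compound 4 (0.37 log units; beyond the scatter) leaves it modestly short of 4-chlorophenyl. Nothing available explains these differences. The compounds shown leave open whether the gain follows the carbonyl or the furan ring, which a plain furan-2-yl or a benzoyl group would help to separate. They also leave open how an amine, a carboxylic acid or a longer alkyl chain would fare at this position.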